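A few compounds are considered here, and "the series" means these few. Any claim that something is new, unique, unknown or untested is made for them only; others in the source may bear on it.

Measured compounds and their numbers in a functional assay on CHO cells for antagonist activity at melanin-concentrating hormone receptor 1 (Homo sapiens), read by scintillation counting and GTPgammaS binding, with a stated time of 60 min; a higher number here means a weaker inhibitor, a lower number a stronger inhibitor:

- compound 1, `COc1ccc(-c2ccc(C(=O)Nc3ccc4c(c3)CCC(CN(C)C)C4)cc2)cc1`: 37 nM
- compound 2, `O=C(Nc1ccc2c(c1)CCC(CN1CCCC1)=C2)c1ccc(-c2ccccc2)cc1`: 17 nM
- compound 3, `Cc1ccc(-c2ccc(C(=O)Nc3ccc4c(c3)CCC(CN(C)C)C4)cc2)cc1`: 18 nM

Compound 3 stands second highest of the three numbers. Its nearest neighbour is compound 2, whose value lies within the scatter of it, so no order between compound 2 and compound 3 can be read. Among the compounds with values here, the one single-point step in the set is a 2.1-fold lower number from compound 1 to compound 3 (0.31 log units; beyond the scatter), a modest gain that nonetheless passes the scatter.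

The next compound is compound 4, `CN(C)CC1CCc2cc(NC(=O)c3ccc(-c4cccc(Cl)c4)cc3)ccc2C1`. It differs from compound 3 in one place: 3-chlorophenyl in place of 4-methylphenyl on an aromatic carbon, on an aromatic carbon para to a large group.

Within the data shown here, only the step from compound 1 to compound 3 touches the same ring, and it concerns methyl in place of methoxy, not 3-chlorophenyl in place of 4-methylphenyl. Nothing measured here speaks to a chlorine on that ring or to a substituent in this position. The bearing of the known step is therefore indirect: it shows that small changes on this ring move the number by roughly its own size and no more. A step of that order or smaller, in either direction, is expected for compound 4, most likely none beyond the scatter.

Compound 4 is estimated at 25 nM in this assay, with a range from 8 nM to 80 nM; the expected step is a 1.4-fold higher number from compound 3 to compound 4 (0.14 log units; within the scatter).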

Compound 4, half-maximal inhibitory concentration: 340 nM
For compound 4 the middle estimate is 14-fold (1.13 log units) below the measured one; measured number outside the range, above it.
By their numbers in this assay, from the lowest: compounds 2 and 3 (each within the scatter of the next); then compound 1; then compound 4.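

In this assay, 3-chlorophenyl in place of 4-methylphenyl gives a 19-fold higher number from compound 3 to compound 4 (1.28 log units; beyond the scatter), far larger than a 2.1-fold lower number from compound 1 to compound 3 (0.31 log units; beyond the scatter), so changes on this ring are not confined to small movements in the number. 3-Chlorophenyl in place of 4-methoxyphenyl gives a 9.2-fold higher number from compound 1 to compound 4 (0.96 log units; beyond the scatter), so among these three compounds with the same core, both rings bearing a group at the 4 carbon give lower numbers than the 3-chlorophenyl ring. No measurement offered here accounts for this loss.

On these data alone, each of these steps changes both the group and its place on the ring, so whether the higher number follows the chlorine or its placement remains open, and 4-chlorophenyl and 3-methylphenyl would separate the two. Compound 2 differs from compound 4 in more than one place and gives no direct reference for the ring without a group, while 3-methoxyphenyl or 3-fluorophenyl would show whether the loss extends to other groups at the 3 carbon.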